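The source may report more compounds than this note shows. Statements on the series, on what has been measured and on what is new or still open speak of the compounds shown alone.

Compound 3 `Cc1cc(NC(=O)CN2CCC(OCc3ccc(F)c(F)c3)CC2)ccc1F` gives 123 nM in an assay on membranes from HEK293 cells for displacement of a labelled ligand from Sigma intracellular receptor 2 (Homo sapiens); a lower number here means a stronger inhibitor, a higher number a weaker inhibitor. Among the three compounds measured there it holds the second highest number: compound 2 `COc1ccc(CN2CCC[C@@H](OCc3ccc(F)c(C)c3)C2)cc1F` gives 206 nM, which lies within the scatter of compound 3, and compound 1 `Fc1cc(COC2CCN(Cc3ccc4[nH]cnc4c3)CC2)ccc1Cl` gives 70 nM, also within the scatter, so no order among the three can be read. Compound 4 `Cc1c(Cl)cccc1NC(=O)CN1CCC(OCc2ccc(F)c(F)c2)CC1` is reached from compound 3 by a single change: 3-chloro-2-methylphenyl in place of 4-fluoro-3-methylphenyl on an amide-type nitrogen. Among the measured compounds shown here, no measured pair shows this change, so its effect is unknown. Lacking such a pair, the step is expected to be modest, estimated as a 1.3-fold higher number from compound 3 to compound 4 (0.11 log units; within the scatter). Compound 4 is accordingly expected to give about 160 nM in this assay, with a range from 50 nM to 500 nM.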

Compound 4, inhibition constant: 299 nM
Estimate against measurement, compound 4: 1.9-fold (0.27 log units) below; the range from low to high includes it.
By their numbers in this assay, from the lowest: compounds 1, 3, 2 and 4 (each within the scatter of the next, the first and the last beyond it).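

On the amide-type nitrogen, the aryl group matters in this assay: 3-chloro-2-methylphenyl in place of 4-fluoro-3-methylphenyl gives a 2.4-fold higher number from compound 3 to compound 4 (0.39 log units; beyond the scatter) and this step lies beyond the scatter, which no earlier comparison could show. The two groups have the same count of heavy atoms, so the number moves without any change in that count. Nothing at hand accounts for the step.

From the compounds shown here alone, whether the chlorine or the placing of the methyl carries it stays open. So does what an unsubstituted phenyl or a pyridyl would give on the same nitrogen.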